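Methoxy to ethoxy on the core of compound 3

The source may hold more compounds than are shown below. What is called first, only, known or untested is meant among the compounds shown, and "the series" means these compounds.

Measured so far:
Compound 1, `C=C(Br)C(=O)Nc1ccc(/C=C/C(=O)c2ccc(OC)cc2)cc1`, gives 1200 nM in a functional assay on FM3A cells (Mus musculus) for antiproliferative activity, with a stated time of 48 h; a higher number here means a weaker inhibitor, a lower number a stronger inhibitor.
Compound 2, `C=C(Br)C(=O)Nc1ccc(/C=C/C(=O)c2ccc(OCC)cc2)cc1`, gives 680 nM in this assay.
Compound 3, `COc1ccc(C(=O)/C=C/c2ccc(N)cc2)cc1`, gives 282000 nM in this assay.

Compound 1 and compound 2 share one core; compound 3 and the unmeasured compound 4, `CCOc1ccc(C(=O)/C=C/c2ccc(N)cc2)cc1`, share another. The two cores differ by hydrogen in place of (1-bromoethenyl)carbonyl on a nitrogen on an aromatic ring. That difference carries the large step of a 240-fold higher number from compound 1 to compound 3 (2.37 log units; beyond the scatter), beyond the scatter, and compound 3 stands at the highest number of the three measured compounds.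

Within the first core, the change methyl in place of hydrogen on a saturated chain carbon bound to an oxygen on an aromatic ring gives a 1.8-fold lower number from compound 1 to compound 2 (0.25 log units; within the scatter), which is within the scatter. The change from compound 3 to compound 4 is methyl in place of hydrogen on a saturated chain carbon bound to an oxygen on an aromatic ring, the same change at the same place, so it is taken as the same kind of step, now made on the core of compound 3 rather than the core of compound 1.

Within the data shown here, the expectation for compound 4 is a step of a 1.4-fold lower number from compound 3 to compound 4 (0.15 log units; within the scatter) in this assay, resting on the one measured instance of this change, a 1.8-fold lower number from compound 1 to compound 2 (0.25 log units; within the scatter). Among the measured compounds shown here, only a single precedent exists and it sits on a different core, so the range is kept wide. Compound 4 is estimated at 200000 nM, between 70000 nM and 600000 nM.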

Compound 4, half-maximal inhibitory concentration: 55000 nM
Beside the measured number, compound 4's estimate is 3.6-fold (0.56 log units) above it, and the stated range ends above it.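

In this assay, methoxy to ethoxy on the core of compound 3 gives a 5.1-fold lower number from compound 3 to compound 4 (0.71 log units; beyond the scatter), so the size of this step does not carry over unchanged from the core of compound 1: the same change on two cores in this assay, a 1.8-fold lower number (0.25 log units; within the scatter) from compound 1 to compound 2 and a 5.1-fold lower number (0.71 log units; beyond the scatter) from compound 3 to compound 4, 2.9-fold (0.46 log units) apart, beyond the scatter of two such steps

Hydrogen in place of (1-bromoethenyl)carbonyl on the nitrogen stays a large step on the ethoxy pair, at an 81-fold higher number from compound 2 to compound 4 (1.91 log units; beyond the scatter), but its size also differs from that on the methoxy pair: the same change on two cores in this assay, a 240-fold higher number (2.37 log units; beyond the scatter) from compound 1 to compound 3 and an 81-fold higher number (1.91 log units; beyond the scatter) from compound 2 to compound 4, 2.9-fold (0.46 log units) apart, beyond the scatter of two such steps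

These two gaps come from the same four compounds and are one observation read two ways, so they show that the two changes do not add independently here, but they do not give a rule for any other core or show which feature of the cores accounts for the gap.

The compounds shown leave open how a longer chain such as propoxy, or a branched one such as isopropoxy, would behave on either core. Also open, on these data alone, is whether the gap between the two ethoxy steps would hold with an acetyl or a plain acryloyl on the nitrogen in place of (1-bromoethenyl)carbonyl.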